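Hydrazone hydrazide series: 2-iodophenyl replacing 4-nitrophenyl

A few compounds are considered here, and "the series" means these few. Any claim that something is new, unique, unknown or untested is made for them only; others in the source may bear on it.

Measured so far:
Compound 1 `COc1cc(C(=O)N/N=C(C)/C=N/Nc2ccc([N+](=O)[O-])cc2)ccc1O`: 5100 nM
Compound 2 `CC(/C=N/Nc1ccc([N+](=O)[O-])cc1)=N\NC(=O)c1ccc([N+](=O)[O-])cc1`: 980 nM

Both numbers come from a functional assay on cells (Splenocyte, Mus musculus, strain BALB/c) for inhibition, read by scintillation counting and thymidine incorporation, with a stated time of 72 h; a higher number here means a weaker inhibitor, a lower number a stronger inhibitor. Among the compounds with values here, compound 2 holds the lowest of the two numbers in this assay; its nearest neighbour is compound 1, and the single measured step, a 5.2-fold lower number from compound 1 to compound 2 (0.72 log units; beyond the scatter), lies beyond the scatter and is modest in size.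

Compound 3 `CC(/C=N/Nc1ccc([N+](=O)[O-])cc1)=N\NC(=O)c1ccccc1I` differs from compound 2 by 2-iodophenyl in place of 4-nitrophenyl on a carbonyl carbon. Within the data shown here, no measured step involves 2-iodophenyl, so the direction rests on one comparison only. Because a 5.2-fold lower number from compound 1 to compound 2 (0.72 log units; beyond the scatter) shows the number falling when 4-nitrophenyl arrives at this carbonyl carbon, its departure in compound 3 is expected to move the number upward rather than downward, though by an uncertain amount. Compound 3 is therefore estimated at 2500 nM in this assay, with a range of 800 nM to 8000 nM. The expected step of a 2.6-fold higher number from compound 2 to compound 3 (0.41 log units; beyond the scatter) is modest and may fall within the scatter.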

Compound 3, half-maximal inhibitory concentration: 2980 nM
Compound 3: the middle estimate sits 1.2-fold (0.08 log units) below what was measured, within the range that was stated.
By their numbers in this assay, from the lowest: compound 2; then compounds 3 and 1 (each within the scatter of the next).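

On the carbonyl carbon, 2-iodophenyl does not match 4-nitrophenyl in this assay (a 3.0-fold higher number from compound 2 to compound 3 (0.48 log units; beyond the scatter)), so the loss seen with 4-hydroxy-3-methoxyphenyl also appears with a second, quite different aryl group. Within the data shown here, compound 3 and compound 1 cannot be separated (a 1.7-fold lower number from compound 1 to compound 3 (0.23 log units; within the scatter)), which leaves compound 2 as the strongest inhibitor of the three and 4-nitrophenyl as the only group here that stands apart. No supporting data bear on why these groups rank this way.

The change from 4-nitrophenyl to 2-iodophenyl alters both the substituent and where it sits on the ring, so the two contributions cannot be separated. Open too, as far as these compounds go, is how 4-iodophenyl, 2-nitrophenyl, or an aryl group carrying an amine or a carboxylic acid would read at this carbonyl carbon.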